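The source may report more compounds than this note shows. Statements on the series, on what has been measured and on what is new or still open speak of the compounds shown alone.

Compound 1 `CCOC(=O)c1sc(-c2cccc(NC(=O)c3ccc(F)cc3)c2)nc1Nc1ccc(N2CCN(C)CC2)cc1` gives 3.53% in a functional assay on Ramos cells (Homo sapiens) for antiproliferative activity, read by CCK-8 assay, with a stated time of 72 h, tested at 40 uM; on this read-out higher numbers stand for more inhibition at the one concentration tested (going by the name of the read-out) and lower numbers for less inhibition.
Compound 2 `CCOC(=O)c1sc(-c2cccc(NC(=O)c3ccccc3)c2)nc1Nc1ccc(N2CCN(C)CC2)cc1` gives 77.1% in this assay.
Compound 3 `CN1CCN(c2ccc(Nc3nc(-c4cccc(NC(=O)c5ccc(F)cc5)c4)sc3C(N)=O)cc2)CC1` gives 95.9% in this assay.

Compound 3 stands highest of the three numbers in this assay. Compound 2 is the nearest to it, and the two values show compound 2 lower beyond the scatter. Compound 1 is the furthest, with a number 92.4 percentage points higher from compound 1 to compound 3 (beyond the scatter), a change of amino in place of ethoxy on a carbonyl carbon.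

Compound 4 `CN1CCN(c2ccc(Nc3nc(-c4cccc(NC(=O)c5ccccc5)c4)sc3C(N)=O)cc2)CC1` keeps the amino group of compound 3 and differs from it in one place: hydrogen in place of fluoro on an aromatic carbon. Among the compounds with values here, the one measured step with the same change is a number 73.6 percentage points higher from compound 1 to compound 2 (beyond the scatter), seen on the pair that carries the ethoxy group instead of the amino group; there it pushed the number strongly upward. Compound 3, however, already sits close to the top of the percentage scale in this assay, so little room is left above it. The expectation for compound 4 is therefore a small upward step, not beyond the scatter: a number 1.1 percentage points higher from compound 3 to compound 4 (within the scatter). Compound 4 is estimated at 97% in this assay, with a likely range from 88% to 100%.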

Compound 4, a percentage reported as inhibition, at one concentration (the size of the read-out at that concentration, not a potency): 98.1%
Estimate against measurement, compound 4: 1.1 percentage points below, within the range that was stated.
By their numbers in this assay, from the lowest: compound 1; then compound 2; then compounds 3 and 4 (each within the scatter of the next).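

In this assay, the swap of 4-fluorophenyl to phenyl does not have one fixed size: on the compounds with the amino group it reads a number 2.2 percentage points higher from compound 3 to compound 4 (within the scatter), so the large gain seen on the compounds with the ethoxy group does not carry over: the same change on two cores in this assay, a number 73.6 percentage points higher (beyond the scatter) from compound 1 to compound 2 and a number 2.2 percentage points higher (within the scatter) from compound 3 to compound 4, 71.4 percentage points apart, beyond the scatter of two such steps The amino-for-ethoxy change likewise depends on what the far end of the molecule carries, and without the fluoro it reads a number 21 percentage points higher from compound 2 to compound 4 (beyond the scatter), still a real gain but a much smaller one: the same change on two cores in this assay, a number 92.4 percentage points higher (beyond the scatter) from compound 1 to compound 3 and a number 21 percentage points higher (beyond the scatter) from compound 2 to compound 4, 71.4 percentage points apart, beyond the scatter of two such steps The two places therefore do not act independently, and the low number of compound 1 appears only where the fluoro and the ethoxy group occur together among these four compounds.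

With compound 3 and compound 4 both close to the top of the percentage scale, a reading at one concentration leaves open whether they differ in potency at all. Going by these compounds, it is also open how the number would respond to a chloro or methoxy group in place of the fluoro, or to a methylamino or hydroxy group in place of the amino group on the carbonyl carbon.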